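A few compounds are considered here, and "the series" means these few. Any claim that something is new, unique, unknown or untested is made for them only; others in the source may bear on it.

In a functional assay on HepG2 cells (Homo sapiens) for cytotoxicity, read by MTT assay, with a stated time of 72 h (on this read-out higher numbers stand for weaker inhibition and lower numbers for stronger inhibition), compound 1 (`CNC(=O)c1cc(Oc2ccc(C3=NNC(c4ccc(F)cc4)C3)cc2)ccn1`) gives 5280 nM. Compound 2 (`CNC(=O)c1cc(Oc2ccc(C3=NN(C(N)=S)C(c4cccc([N+](=O)[O-])c4)C3)cc2)ccn1`) reaches only a limit of the assay, > 50000 nM, so it has no exact number. Compound 3 (`CNC(=O)c1cc(Oc2ccc(C3=NN(C(N)=S)C(c4ccc(F)cc4)C3)cc2)ccn1`) differs from compound 2 in one place: 4-fluorophenyl in place of 3-nitrophenyl on a saturated ring carbon, with 4-fluorophenyl in place of 3-nitrophenyl on a saturated ring carbon. Compound 1 also carries 4-fluorophenyl and gives 5280 nM, which points to an expected move toward stronger inhibition. The estimated step runs an at least 2.5-fold lower number from compound 2 to compound 3 (0.39 log units; beyond the scatter). For compound 3, the expected value is 20000 nM, within an estimated range of 5000 nM to 50000 nM.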

Compound 3, half-maximal inhibitory concentration: > 50000 nM
Compound 3 ended at the assay's limit; the forecaster's own chance of this, stated with the estimate: 30%; middle value at least 2.5-fold (0.39 log units) away from the limit.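

In this assay, a group of 3 heavy atoms (carbon, nitrogen and sulfur) in place of the hydrogen on the amine nitrogen in the ring gives an at least 9.4-fold higher number from compound 1 to compound 3 (0.97 log units; beyond the scatter), so with 4-fluorophenyl kept, this change weakens inhibition. The swap of 3-nitrophenyl for 4-fluorophenyl on the saturated ring carbon cannot be read, because compound 2 and compound 3 both give a limit and not a number: the limit of > 50000 nM in this assay, at which 2 of the 3 values shown sit.

As far as these compounds go, it remains open what an acetyl group on that ring nitrogen would give. Also open, from the compounds shown here alone, is how 3-nitrophenyl compares with 4-fluorophenyl when that nitrogen carries only hydrogen.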